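Swapping benzofuran for indole on an amide series

This account rests on a few compounds, and the source may have more. Where it says the series, first, only, none or still open, it means among the compounds named here.

Compound 3, `CCCCCCCCCCCCCCCCCCNC(=O)[C@@H](NC(=O)c1cc2ccccc2o1)[C@@H](C)O`, is known in a functional assay on HepG2 cells (Homo sapiens) for cytotoxicity, read by MTT assay, with a stated time of 48 h (a higher number here means a weaker inhibitor, a lower number a stronger inhibitor), only by a limit, giving > 200000 nM; it sits at the ceiling described by the limit of > 200000 nM in this assay, at which 1 of the 3 values shown sits. The parent amine, compound 1, `CCCCCCCCCCCCCCCCCCNC(=O)[C@@H](N)[C@@H](C)O`, gives 44500 nM in this assay, so the step of an at least 4.4-fold higher number from compound 1 to compound 3 (0.65 log units; beyond the scatter) marks the addition of the benzofuran carbonyl. Compound 2, `CCCCCCCCCCCCCCNC(=O)[C@@H](NC(=O)c1cc2ccccc2[nH]1)[C@@H](C)O`, which carries an indole carbonyl on a shorter chain, gives 10500 nM in this assay.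

Compound 4, `CCCCCCCCCCCCCCCCCCNC(=O)[C@@H](NC(=O)c1cc2ccccc2[nH]1)[C@@H](C)O`, differs from compound 3 by 1H-indol-2-yl in place of 1-benzofuran-2-yl on a carbonyl carbon. Within the data shown here, no measured step covers this exact exchange. Among the measured compounds shown here, the only step involving compound 3 concerns attaching the benzofuran carbonyl, and the indole-bearing compound 2 is among the lower numbers seen, while compound 3 sits at a limit. The step of an at least 5.0-fold lower number from compound 3 to compound 4 (0.69 log units; beyond the scatter) is therefore expected to run toward a lower number, though its size is uncertain. Compound 4 is estimated at 40000 nM in this assay, within a range from 8000 nM to 200000 nM.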

Compound 4, half-maximal inhibitory concentration: 89400 nM
Estimate against measurement, compound 4: 2.2-fold (0.35 log units) below, and the stated range covers the measured number.
By their numbers in this assay, from the lowest: compound 2; then compounds 1 and 4 (each within the scatter of the next). At a limit, above all of these: compound 3.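

In this assay, 1H-indol-2-yl in place of 1-benzofuran-2-yl on the carbonyl carbon gives an at least 2.2-fold lower number from compound 3 to compound 4 (0.34 log units; beyond the scatter), the first sign that this exchange alone separates the two acylated amines. Placing (1H-indol-2-yl)carbonyl on the amine nitrogen gives a 2.0-fold higher number from compound 1 to compound 4 (0.30 log units; within the scatter), unlike the benzofuran carbonyl, while the chain also matters with the indole in place, as butyl in place of hydrogen on a saturated chain carbon gives an 8.5-fold higher number from compound 2 to compound 4 (0.93 log units; beyond the scatter). Compound 3 is known only by a limit, so the exchange has a bound and no exact size: the limit of > 200000 nM in this assay, at which 1 of the 4 values shown sits.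

As far as these compounds go, it remains open whether a 1-benzothiophen-2-yl carbonyl, with sulfur in the ring, would track the indole or the benzofuran. The shorter chain of compound 2 also leaves open how a benzofuran carbonyl would read on that chain.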